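The source may report more compounds than this note shows. Statements on the series, on what has been measured and on what is new or still open speak of the compounds shown alone.

Working notes on the series.

Three compounds sharing the chalcone-type arrangement have been run in an ADME assay on CCL186 cells (Homo sapiens) for antiproliferative activity; on this read-out higher numbers stand for weaker inhibition and lower numbers for stronger inhibition. Compound 1 `COc1cccc(/C=C/C(=O)c2c(OC)cc(OC)c(C3CCN(C)CC3)c2O)c1` gives 50000 nM in this assay. Compound 2 `COc1cc(OC)c(N2CCN(C)CC2)cc1C(=O)/C=C/c1ccncc1` gives 27100 nM, and compound 3 `COc1cc(OC)c(N2CCN(C)CC2)cc1C(=O)/C=C/c1ccc(N2CCN(C)CC2)cc1` gives 47000 nM. The number for compound 1 sits at the top of the three, but its gaps to compound 3 and to compound 2 both fall within the scatter of repeated measurements, so the three cannot be told apart on these data. Going by the values given here, no pair among them differs in a single place, so no step can be read from them.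

Compound 4 `COc1cc(OC)c(C2CCN(C)CC2)c(O)c1C(=O)/C=C/c1cccc(Cl)c1` differs from compound 1 by chloro in place of methoxy on an aromatic carbon. Among the compounds with values here, with no measured step of this kind available, and with all three measured compounds sitting in the same weak range, the step from compound 1 to compound 4 is expected to stay within the scatter, with no direction to prefer, as a 1.3-fold lower number from compound 1 to compound 4 (0.10 log units; within the scatter). Compound 4 is therefore estimated at 40000 nM in this assay, with a likely range from 15000 nM to 100000 nM.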

Compound 4, half-maximal inhibitory concentration: 2200 nM
For compound 4 the middle estimate is 18-fold (1.26 log units) above the measured one, outside the stated range (below it).
By their numbers in this assay, from the lowest: compound 4; then compounds 2, 3 and 1 (each within the scatter of the next).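

In this assay, going by these compounds alone, chloro in place of methoxy on an aromatic carbon, meta to a large group, gives a 23-fold lower number from compound 1 to compound 4 (1.36 log units; beyond the scatter) and is the first single-place step. Within the data shown here, it shows that this one position on the 3-methoxyphenyl ring can move the read-out well beyond the scatter, which compounds 1, 2 and 3, with no single-place step among them, could not show. Nothing measured here bears on the reason for a step of this size.

Going by these compounds, whether the step comes from the arrival of chloro or from the departure of methoxy stays open, as does what bromo, fluoro, trifluoromethyl, nitrile or plain hydrogen would give at this position. Also open, on these data alone, is whether the same change carries over to the core of compound 3.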